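Swapping piperidin-1-yl for pyrrolidin-1-yl in compound 1

The source may report more compounds than this note shows. Statements on the series, on what has been measured and on what is new or still open speak of the compounds shown alone.

Measured so far in a physicochemical assay for lipophilicity; on this read-out lower numbers stand for lower lipophilicity and higher numbers for higher lipophilicity:
compound 1 `CC(C)=CCC/C(C)=C/CC/C(C)=C/CSC[C@H](NC(=O)CCCCCN1CCCC1)C(=O)N1CCCCC1` gives 3.76
compound 2 `CC(C)=CCC/C(C)=C/CC/C(C)=C/CSC[C@H](NC(=O)CCCCCN1CCN(C)CC1)C(=O)N1CCCCC1` gives 4.27
compound 3 `CC(C)=CCC/C(C)=C/CC/C(C)=C/CSc1ccccc1C(N)=O` gives 6.03

Among these three, compound 1 has the lowest number in this assay. Its nearest neighbour on the scale is compound 2, and compound 3 lies furthest away. The next compound to be measured is compound 4 `CC(C)=CCC/C(C)=C/CC/C(C)=C/CSC[C@H](NC(=O)CCCCCN1CCCC1)C(=O)N1CCCC1`, which keeps the core of compound 1 and changes one group: pyrrolidin-1-yl in place of piperidin-1-yl on a carbonyl carbon. In words, pyrrolidin-1-yl stands in place of piperidin-1-yl on a carbonyl carbon.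

Going by the values given here, only one measured step is available, and it bears on this change only loosely. That step, a number 0.51 log units higher from compound 1 to compound 2 (beyond the scatter), is a modest one, and it comes from 4-methylpiperazin-1-yl in place of pyrrolidin-1-yl on a saturated chain carbon, not from a change on the carbonyl carbon. Among the compounds with values here, no measured pair tests the piperidin-1-yl group itself, and compound 3 differs too widely to supply a step. A modest fall is therefore expected, of about the size of the step to compound 2 or somewhat smaller, though this rests on thin evidence. The expected step is a number 0.36 log units lower from compound 1 to compound 4 (beyond the scatter). For compound 4 the estimated value is 3.4, with an expected range from 3 to 3.8.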

Compound 4, distribution coefficient: 3.31
Compound 4: middle estimate off by 0.09 log units, on the high side; measured number inside the range.
By their numbers in this assay, from the lowest: compound 4; then compound 1; then compound 2; then compound 3.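

The carbonyl-bound group proves to be a second place where the number in this assay can move: with pyrrolidin-1-yl in place of piperidin-1-yl, the result is a number 0.45 log units lower from compound 1 to compound 4 (beyond the scatter) while the rest of the structure, including the pyrrolidin-1-yl on the chain, stays the same. Going by these compounds alone, the only earlier step, a number 0.51 log units higher from compound 1 to compound 2 (beyond the scatter) in the opposite direction, came from a change on a saturated chain carbon, so the two steps now show that a change at either place takes the number beyond the usual scatter, though they cannot be compared as the same change. Nothing available explains why replacing the six-membered ring with a five-membered ring on the carbonyl carbon gives a step of this size.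

On these data alone, it remains open whether the same swap would give a similar step in a compound carrying 4-methylpiperazin-1-yl on the chain, as compound 2 does. Also unsettled is how other groups on the carbonyl carbon, such as morpholin-4-yl, azetidin-1-yl or an open-chain dimethylamino group, would compare with pyrrolidin-1-yl and piperidin-1-yl.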